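This account rests on a few compounds, and the source may have more. Where it says the series, first, only, none or still open, it means among the compounds named here.

Measured compounds:
compound 1 `Cc1ccc(NC(=O)Nc2cc(C)nc3ccccc23)cc1` — 669 10^-6 cm/s
compound 2 `COc1ccc(NC(=O)Nc2cc(C)nc3ccccc23)cc1Cl` — 336 10^-6 cm/s
compound 3 `Cc1cc(NC(=O)Nc2cccc(C(C)(C)C)c2)c2ccccc2n1` — 555 10^-6 cm/s

All three were run in an ADME assay for permeability, using PAMPA, at pH 7.4; on this read-out higher numbers stand for higher permeability and lower numbers for lower permeability. On the numbers shown, compound 1 stands close to compound 3, the gap between them lying within the scatter of repeated measurement, and its gap to compound 2, the furthest of the three, also lies within the scatter. The three values therefore cannot be told apart with confidence, and no ordering among compound 1, compound 2 and compound 3 is supported by the data.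

Compound 4 `CCc1ccc(NC(=O)Nc2cc(C)nc3ccccc23)cc1` has not yet been measured in this assay. It differs from compound 1 in one place: methyl in place of hydrogen on a saturated chain carbon bound to an aromatic carbon. Read one bond further out, the same change is methyl to ethyl. Among the compounds with values here, no step between measured compounds covers this change, so the expectation rests only on the numbers of compound 1, compound 2 and compound 3 and on the small size of the change.

Given 669 10^-6 cm/s for compound 1, compound 4 is expected to show a step of a 1.1-fold lower number from compound 1 to compound 4 (0.05 log units; within the scatter), which is no step beyond the scatter. The estimate for compound 4 in this assay is 600 10^-6 cm/s, with a range from 350 10^-6 cm/s to 1000 10^-6 cm/s.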

Compound 4, apparent permeability: 535 10^-6 cm/s
For compound 4 the middle estimate is 1.1-fold (0.05 log units) above the measured one, within the range that was stated.
By their numbers in this assay, from the lowest: compounds 2, 4, 3 and 1 (each within the scatter of the next).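

Within the data shown here, until now the series offered no step confined to one place, so this pair is the first direct reading of a change at this position. In this assay, methyl in place of hydrogen on a saturated chain carbon bound to an aromatic carbon gives a 1.3-fold lower number from compound 1 to compound 4 (0.10 log units; within the scatter), so the step from methyl to ethyl cannot be told apart from repeat scatter. At this position, the single added carbon therefore leaves no readable mark on the read-out, and no measurement available here bears on any cause for the small step.

Going by these compounds, whether a longer chain such as propyl, a branched group such as isopropyl, or a chain ending in an amine or a carboxylic acid at this same place would also stay within the scatter of compound 1 remains open. Also open, on these data alone, is whether methyl to ethyl would read the same way on a compound carrying other groups, since this single pair tests the change only on the background of compound 1.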